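Swapping the amide aryl group in a cytotoxicity series

The compounds below may be only part of what the source reports. "The series", "measured", "known", "first", "only" and "open" are said of these compounds alone.

Compound 1 `COc1cc2nc(C)cc(OCC(=O)Nc3cc(C)cc(C)c3)c2cc1OC` gives 10000 nM in a toxicity assay on HepG2 cells (Homo sapiens) for inhibition, read by CellTiter-Glo, with a stated time of 48 h; a lower number here means a stronger inhibitor, a higher number a weaker inhibitor.
Compound 2 `COc1ccc2nc(C)cc(OC(C)(C)C(=O)Nc3cc(C)cc(C)c3)c2c1` reaches only the limit of > 100000 nM in this assay.
Compound 3 `COc1ccc2nc(C)cc(OCC(=O)Nc3c(C)cccc3C)c2c1` likewise reaches only the limit of > 100000 nM in this assay.

Compound 3 thus stands at a limit rather than at a number, as do two of the three values shown (the limit of > 100000 nM in this assay, at which 2 of the 3 values shown sit). Compound 4 `COc1ccc2nc(C)cc(OCC(=O)Nc3cc(C)c(F)c(C)c3)c2c1` differs from it in one place: 4-fluoro-3,5-dimethylphenyl in place of 2,6-dimethylphenyl on an amide-type nitrogen. Within the data shown here, no step between measured compounds is available here, and only compound 1 supplies a number, 10000 nM. The change is expected to move the value little beyond the usual scatter, and the estimated step of an at least 2.5-fold lower number from compound 3 to compound 4 (0.39 log units; beyond the scatter) is small. Compound 4 is expected to give about 40000 nM in this assay, within 8000 nM to 100000 nM, with a fair chance that only a limit is reported again.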

Compound 4, half-maximal inhibitory concentration: > 100000 nM
Compound 4 ended at the assay's limit; the forecaster's own chance of this, stated with the estimate: 45%; at least 2.5-fold (0.39 log units) between middle value and limit.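

Compound 3 and compound 4 both end at a limit rather than a number in this assay, so no step between them can be read: the limit of > 100000 nM in this assay, at which 3 of the 4 values shown sit.

The compounds shown leave open whether 4-fluoro-3,5-dimethylphenyl in place of 2,6-dimethylphenyl changes the value at all.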